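The source may report more compounds than this note shows. Statements on the series, on what has been measured and on what is new or still open speak of the compounds shown alone.

Working notes on the series. The shared core is that of compound 1 `CC(C)(C)Nc1nc(N)c(C(=O)N=C(N)N)nc1Cl`; in an assay for inhibition of acid-sensing ion channel 3 (Homo sapiens), read by patch clamp, tested at 1 uM (on this read-out lower numbers stand for less inhibition and higher numbers for more inhibition at the one concentration tested (going by the name of the read-out)), compound 1 has "not determined" (no result reported), so it stands without a number. The same holds for compound 3 `NC(N)=NC(=O)c1nc(Cl)c(N2CCCCC2)nc1N`: in this assay compound 3 has "not determined" (no result reported), so no inhibition value is given for it either. Among the measured compounds shown here, the only measured point is compound 2 `CCCN(C)c1nc(N)c(C(=O)N=C(N)N)nc1Cl`: in this assay compound 2 gives 32%. Compound 4 `NC(N)=NC(=O)c1nc(Cl)c(Nc2cccc(Cl)c2)nc1N` is not yet measured. It differs from compound 1 by 3-chlorophenyl in place of tert-butyl on a nitrogen on an aromatic ring. For the measured compounds named here, no step between measured compounds is known, so no direction can be read from the data; a change of this assay within the usual scatter of the single known value is expected rather than a large move in either direction. Compound 4 is estimated at 35%, within 10% to 65%.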

Compound 4, a percentage reported as inhibition, at one concentration (the size of the read-out at that concentration, not a potency): 47%
Beside the measured number, compound 4's estimate is 12 percentage points below it; low and high end bracket the measured number.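

Among the compounds shown here, with compound 1 at "not determined" (no result reported) in this assay no step to compound 4 can be read. On these data alone, what 3-chlorophenyl in place of tert-butyl does to inhibition stays open, and no supporting data bear on the result of compound 4.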